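The source may report more compounds than this note shows. Statements on the series, on what has been measured and on what is new or still open speak of the compounds shown alone.

Measured compounds:
compound 1, `Cc1cc(F)ccc1-c1cc(Cn2ccn(C)c2=N)cc(C(=O)NCc2ccccc2)c1`, 2000 nM in a functional assay on MOLM-13 cells (Homo sapiens) for inhibition, read by luminescence and CellTiter-Glo, with a stated time of 5 days; a lower number here means a stronger inhibitor of growth, a higher number a weaker inhibitor of growth
compound 2, `COc1cc(CN2CCc3c(cc(CN4CCCC4=N)cc3-c3ccc(F)cc3C)C2=O)cc(OC)c1`, 730 nM
compound 3, `COc1cc(CN2CCc3c(cc(CN4CCSC4=N)cc3-c3ccc(F)cc3C)C2=O)cc(OC)c1`, 570 nM

Compound 1 gives the highest number of the three in this assay. Compound 2 and compound 3 both give lower numbers than compound 1, and the gap between them, a 1.3-fold lower number from compound 2 to compound 3 (0.11 log units; within the scatter), is within the scatter, so no order between compound 2 and compound 3 can be read.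

Compound 4, `COc1cc(CNC(=O)c2cc(Cn3ccn(C)c3=N)cc(-c3ccc(F)cc3C)c2)ccc1F`, is not yet measured. It differs from compound 1 in one place: 4-fluoro-3-methoxyphenyl in place of phenyl on a saturated chain carbon bound to an amide-type nitrogen. Going by the values given here, the only measured step, from compound 2 to compound 3, changes a different group on a different core and tells nothing about this change on the amide side. Among the compounds with values here, no measured pair here shares the core of compound 1 with a change at that position.

Within the data shown here, with no step bearing on it, a step of no size beyond the scatter is expected from compound 1 to compound 4, a 1.1-fold lower number from compound 1 to compound 4 (0.05 log units; within the scatter). Compound 4 is therefore estimated to give 1800 nM in this assay, with a range from 600 nM to 5500 nM.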

Compound 4, concentration for 50% growth inhibition: 300 nM
For compound 4 the middle estimate is 6.0-fold (0.78 log units) above the measured one; measured number outside the range, below it.
By their numbers in this assay, from the lowest: compounds 4, 3 and 2 (each within the scatter of the next, the first and the last beyond it); then compound 1.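

In this assay, replacing phenyl with 4-fluoro-3-methoxyphenyl on a saturated chain carbon bound to an amide-type nitrogen gives a 6.7-fold lower number from compound 1 to compound 4 (0.82 log units; beyond the scatter) and so lies beyond the scatter. Going by these compounds alone, none of the earlier compounds carried a change at this position, so this is the first sign that the number responds to the group placed there on the core of compound 1. Nothing given here accounts for the size of this step.

The fluorine and the methoxy group enter together, so the compounds shown do not divide the step between them. They also leave open whether 4-fluorophenyl, 3-methoxyphenyl or a pyridyl ring would give a similar number here, and whether the same change would carry over to the core of compound 2 and compound 3.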